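Benzylic ether to ester on the biaryl tail

The compounds below may be only part of what the source reports. "The series", "measured", "known", "first", "only" and "open" are said of these compounds alone.

Compound 3 `CC[C@H](C)[C@H](N)CN(C(=O)[C@@H]1C[C@H]1c1ccccc1)c1ccc(-c2ccc(COC(C)(C)C)cc2)cc1` gives 280 nM in a functional assay for agonist activity at G protein-coupled receptor 88 (Homo sapiens), read by HTRF and cAMP accumulation (a higher number here means that more compound is needed for the effect, a lower number that less compound is needed), the second highest of three numbers. Compound 2 `CC[C@H](C)[C@H](N)CN(C(=O)[C@@H]1C[C@H]1c1ccccc1)c1ccc(-c2ccc(C(F)(F)F)cc2)cc1` gives 340 nM and compound 1 `CCc1ccc(-c2ccc(N(C[C@@H](N)[C@@H](C)CC)C(=O)[C@@H]3C[C@H]3c3ccccc3)cc2)cc1` gives 44 nM; the step of a 6.4-fold higher number from compound 1 to compound 3 (0.80 log units; beyond the scatter) is beyond the scatter, the step of a 1.2-fold lower number from compound 2 to compound 3 (0.08 log units; within the scatter) is not. Compound 4 `CC[C@H](C)[C@H](N)CN(C(=O)[C@@H]1C[C@H]1c1ccccc1)c1ccc(-c2ccc(CCC(=O)OC)cc2)cc1` differs from compound 3 by (methoxycarbonyl)methyl in place of tert-butoxy on a saturated chain carbon bound to an aromatic carbon. Among the compounds with values here, no measured pair shows this exact exchange; the nearest guide is that compound 2 and compound 3 carry different tail groups of similar size and sit within the scatter of each other, while only the small ethyl of compound 1 reads lower. A step of a 1.1-fold higher number from compound 3 to compound 4 (0.03 log units; within the scatter) is therefore expected, with no change beyond the scatter. Compound 4 is estimated at 300 nM, range 120 nM to 800 nM.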

Compound 4, half-maximal effective concentration: 110 nM
For compound 4 the middle estimate is 2.7-fold (0.44 log units) above the measured one; measured number below the stated range.
By their numbers in this assay, from the lowest: compound 1; then compound 4; then compounds 3 and 2 (each within the scatter of the next).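

In this assay the larger tail groups are not interchangeable at this position: a 2.5-fold lower number from compound 3 to compound 4 (0.41 log units; beyond the scatter) and a 3.1-fold lower number from compound 2 to compound 4 (0.49 log units; beyond the scatter) set 2-(methoxycarbonyl)ethyl apart from (tert-butoxy)methyl and trifluoromethyl, which lie within the scatter of each other. Heavy-atom count does not settle the number, as tert-butoxy and (methoxycarbonyl)methyl have equal counts. Ethyl keeps the lowest number, with a 2.5-fold higher number from compound 1 to compound 4 (0.40 log units; beyond the scatter) on adding methoxycarbonyl to its chain, and no measurement here accounts for these steps.

Still open, going by these compounds, is whether a carboxylic acid or a primary amide on this chain reads like methoxycarbonyl, and how a longer chain would read.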